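A few compounds are considered here, and "the series" means these few. Any claim that something is new, unique, unknown or untested is made for them only; others in the source may bear on it.

In an ADME assay on MDCK cells (Canis lupus familiaris) for cytotoxicity, read by MTT assay, with a stated time of 3 days (a lower number here means that less compound is tolerated, a higher number that more compound is tolerated), compound 3 `CC1(C)C[C@H](O)C[C@](C)(CNc2cc(F)cc(S(N)(=O)=O)c2)C1` gives 55000 nM, the highest number among the three measured compounds. Compound 1 `CC1(C)C[C@H](O)C[C@](C)(CNc2cccc(C(F)(F)F)c2)C1` gives 7800 nM and compound 2 `CC1(C)C[C@H](O)C[C@](C)(CNc2cc(Cl)cc(C(F)(F)F)c2)C1` gives 6700 nM; the step of a 1.2-fold lower number from compound 1 to compound 2 (0.07 log units; within the scatter) shows that adding a chloro group left the read-out essentially unchanged. Compound 4 `CC1(C)C[C@H](O)C[C@](C)(CNc2cc(C(F)(F)F)cc(S(N)(=O)=O)c2)C1` differs from compound 3 by trifluoromethyl in place of fluoro on an aromatic carbon, on the aromatic carbon meta to the sulfamoyl group. Going by the values given here, no measured step swaps fluoro for trifluoromethyl, and the only halogen step available, a 1.2-fold lower number from compound 1 to compound 2 (0.07 log units; within the scatter), was small. A similarly modest movement is therefore expected, perhaps a slight drop in the tolerated concentration, so compound 4 is estimated at 30000 nM, with a range from 10000 nM to 80000 nM, corresponding to an expected step of a 1.8-fold lower number from compound 3 to compound 4 (0.26 log units; within the scatter).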

Compound 4, half-maximal cytotoxic concentration: 19500 nM
Compound 4: the middle estimate sits 1.5-fold (0.19 log units) above what was measured; the range from low to high includes it.
By their numbers in this assay, from the lowest: compounds 2 and 1 (each within the scatter of the next); then compound 4; then compound 3.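

In this assay, going by these compounds alone, trifluoromethyl in place of fluoro at this carbon, meta to a sulfamoyl group, gives a step beyond the scatter (a 2.8-fold lower number from compound 3 to compound 4 (0.45 log units; beyond the scatter)), unlike the chloro step among the earlier compounds. With trifluoromethyl kept, sulfamoyl moves the number the other way, whether it replaces chloro (a 2.9-fold higher number from compound 2 to compound 4 (0.46 log units; beyond the scatter)) or hydrogen (a 2.5-fold higher number from compound 1 to compound 4 (0.40 log units; beyond the scatter)). Nothing measured here gives a reason for either direction. On these data alone, what a methyl, a nitrile or a carboxylic acid would do at this carbon stays open.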